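Shortening the Amino Acid Side Chain on Compound 2

The source may hold more compounds than are shown below. What is called first, only, known or untested is meant among the compounds shown, and "the series" means these compounds.

Going by the values given here, compound 2 `COC(=O)[C@H](NC(=O)Cn1cc(C2=C(c3c[nH]c4ccccc34)C(=O)N(C)C2=O)c2ccccc21)[C@@H](C)O` is the only member of this set with an actual number in a functional assay on BGC-823 cells (Homo sapiens) for cytotoxicity, read by MTT assay, with a stated time of 24 h; a higher number here means a weaker inhibitor, a lower number a stronger inhibitor: compound 2 gives 23300 nM. Compound 1 `CC[C@H](C)[C@@H](NC(=O)Cn1cc(C2=C(c3c[nH]c4ccccc34)C(=O)N(C)C2=O)c2ccccc21)C(=O)OC` reaches only a limit of the assay, reported as > 100000 nM. Among the compounds with values here, the one measured step, an at least 4.2-fold lower number from compound 1 to compound 2 (0.63 log units; beyond the scatter), therefore has a known lower bound but no fixed size, because it rests on (the limit of > 100000 nM in this assay, at which 1 of the 2 values shown sits).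

Compound 3 `COC(=O)[C@@H](C)NC(=O)Cn1cc(C2=C(c3c[nH]c4ccccc34)C(=O)N(C)C2=O)c2ccccc21` differs from compound 2 by methyl in place of 1-hydroxyethyl on a saturated chain carbon bound to an amide-type nitrogen and a carbonyl carbon. The side chain thus loses its hydroxy group and one carbon. In the measured step, arrival of a hydroxy group on that side chain went with a lower number, so its removal is expected to move the number back up, although compound 3 also carries a smaller group than compound 1 did, which the data cannot weigh. The expected step is a 2.1-fold higher number from compound 2 to compound 3 (0.33 log units; beyond the scatter), toward weaker inhibition. Compound 3 is estimated to give 50000 nM in this assay, with a likely range from 15000 nM to 150000 nM, and a real chance that only a limit is reported.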

Compound 3, half-maximal inhibitory concentration: 60400 nM
Compound 3: the middle estimate sits 1.2-fold (0.08 log units) below what was measured; low and high end bracket the measured number.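

The new step tests the side chain from a second direction: in this assay, replacing 1-hydroxyethyl with methyl on this carbon gives a 2.6-fold higher number from compound 2 to compound 3 (0.41 log units; beyond the scatter). Compound 2, the only one of the three with a hydroxy group on the side chain, now has the lowest number, with steps beyond the scatter against both the larger sec-butyl of compound 1 and the smaller methyl of compound 3, so among these compounds the number does not simply follow side-chain size. Replacing sec-butyl with methyl gives an at least 1.6-fold lower number from compound 1 to compound 3 (0.21 log units; that floor lies within the scatter), which sets no firm order for that pair, and the value for compound 1 is a limit of the assay, not a number: the limit of > 100000 nM in this assay, at which 1 of the 3 values shown sits.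

The step from compound 2 to compound 3 removes the hydroxy group and carbon together, so the compounds shown cannot say which of the two changes goes with the higher number. On these data alone, a hydroxymethyl group on this carbon would bear on that question, and how a free carboxylic acid in place of the methyl ester would read also remains open.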